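From a Pyrazole to an Ethylsulfonamide on the Indane Core

The source may hold more compounds than are shown below. What is called first, only, known or untested is meant among the compounds shown, and "the series" means these compounds.

Compound 1 `c1cc(-c2ccn[nH]2)c2c(c1)C(c1ncc[nH]1)CC2` was tested in a functional assay on CHO cells for agonist activity at Alpha-1A adrenergic receptor (Homo sapiens), read by FLIPR and calcium flux (on this read-out higher numbers stand for larger maximal responses and lower numbers for smaller maximal responses), where compound 1 gives 83%. Among the compounds with a single number, compound 1 stands highest. The nearest is compound 2 `Cc1c(OCC2=NCCN2)ccc(Cl)c1NS(C)(=O)=O`, which in this assay gives 60%, a value lower than that of compound 1 by more than the usual scatter. Compound 3 `CS(=O)(=O)Nc1cccc2c1CCCC2c1ncc[nH]1` carries a methylsulfonylamino group on a core of two fused rings and has several entries: in this assay compound 3 gives 47%; 79%; 79% (3 entries), and these repeats the several entries of compound 3 in this assay, 47%; 79%; 79% (3 entries) show that one of them sits well apart from the other two.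

Compound 4 `CCS(=O)(=O)Nc1cccc2c1CCC2c1ncc[nH]1` is not yet measured. It keeps the shared core of compound 1, with one change: (ethylsulfonyl)amino in place of 1H-pyrazol-5-yl on an aromatic carbon. The change places compound 4 close in kind to compound 3, whose values fall mostly not far from that of compound 1. The step from compound 1 to compound 4 is therefore expected to be small, in either direction, and likely within the scatter, with a number 11 percentage points lower from compound 1 to compound 4 (beyond the scatter) as the estimate. For compound 4 in this assay the estimate is 72%, with a range from 45% to 92%.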

Compound 4, largest response reached (Emax), in percent of the reference or control that the assay uses: 86%
For compound 4 the middle estimate is 14 percentage points below the measured one; measured number inside the range.
By their numbers in this assay, from the lowest: compound 2; then compounds 1 and 4 (each within the scatter of the next).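

In this assay, putting (ethylsulfonyl)amino in place of 1H-pyrazol-5-yl on an aromatic carbon of the shared core gives a number 3 percentage points higher from compound 1 to compound 4 (within the scatter). For this pair, the large maximal response therefore does not depend on a five-membered aromatic ring at this position, since a group with no ring, two double bonds outside aromatic rings and one more hydrogen-bond acceptor serves with no change beyond the scatter. The earlier compounds could not show this, as they offered no pair differing in one place, and compound 3 gave no single number to lean on: the several entries of compound 3 in this assay, 47%; 79%; 79% (3 entries)

What the compounds shown leave open is whether this holds for other groups on the same aromatic carbon, such as an amine, a carboxylic acid or a longer chain on the sulfonyl group in place of ethyl. They also leave open whether the same exchange would give a similar result at another place on the shared core, as this single step speaks only for the one position and only for the largest response reached.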